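This account rests on a few compounds, and the source may have more. Where it says the series, first, only, none or still open, it means among the compounds named here.

Compound 1 `O=S(=O)(NCCCNCc1ccccc1Cl)c1cc(C(F)(F)F)cc(C(F)(F)F)c1`: 13000 nM
Compound 2 `O=S(=O)(NCCCCNCc1ccc(Br)cc1)c1cc(C(F)(F)F)cc(C(F)(F)F)c1`: 1900 nM
Compound 3 `O=S(=O)(NCCCNCC1COc2ccccc2O1)c1cc(C(F)(F)F)cc(C(F)(F)F)c1`: 2500 nM

In a functional assay on Capan-2 cells (Homo sapiens) for inhibition, read by MTT assay, with a stated time of 72 h (a lower number here means a stronger inhibitor of growth, a higher number a weaker inhibitor of growth), compound 3 stands second highest of the three numbers. Its nearest neighbour is compound 2, which lies within the scatter, and compound 1 sits furthest from it, separated by the step of a 5.2-fold lower number from compound 1 to compound 3 (0.72 log units; beyond the scatter).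

Compound 4 `O=S(=O)(NCCCNCc1ccccc1)c1cc(C(F)(F)F)cc(C(F)(F)F)c1` differs from compound 3 by phenyl in place of 2,3-dihydro-1,4-benzodioxin-2-yl on a saturated chain carbon bound to an amine nitrogen. The step of a 5.2-fold lower number from compound 1 to compound 3 (0.72 log units; beyond the scatter) bears on this change, since it replaced a group on the same chain carbon and lowered the number modestly. Compound 4 now gives up that group for plain phenyl, which resembles the aryl of compound 1 without its chlorine. The step of a 6.8-fold lower number from compound 1 to compound 2 (0.84 log units; beyond the scatter) concerns a different alteration and speaks less directly. The expectation is therefore a modest rise, a 2.4-fold higher number from compound 3 to compound 4 (0.38 log units; beyond the scatter), landing between compound 3 and compound 1. Compound 4 is estimated at 6000 nM, within a range from 2000 nM to 18000 nM.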

Compound 4, concentration for 50% growth inhibition: 14000 nM
Compound 4: middle estimate off by 2.3-fold (0.37 log units), on the low side; the measured number falls inside the stated range.
By their numbers in this assay, from the lowest: compounds 2 and 3 (each within the scatter of the next); then compounds 1 and 4 (each within the scatter of the next).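

In this assay, hydrogen in place of chloro on an aromatic carbon leaves the number within the scatter (a 1.1-fold higher number from compound 1 to compound 4 (0.03 log units; within the scatter)), so the chlorine does not separate compound 1 from compound 4. Plain phenyl gives up what the 2,3-dihydro-1,4-benzodioxin-2-yl had gained (a 5.6-fold higher number from compound 3 to compound 4 (0.75 log units; beyond the scatter)), and compound 2 also lies beyond the scatter from this unsubstituted benzyl compound (a 7.4-fold higher number from compound 2 to compound 4 (0.87 log units; beyond the scatter)). No measurement given here explains these differences.

The compounds shown do not separate the bromo of compound 2 from its chain length. On these data alone, whether a pyridyl or a methoxyphenyl on this chain carbon would match compound 3 remains open.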